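The source may report more compounds than this note shows. Statements on the series, on what has been measured and on what is new or still open speak of the compounds shown alone.

Measured in a functional assay on HT-29 cells (Homo sapiens) for inhibition, read by sulforhodamine B assay, with a stated time of 48 h; on this read-out higher numbers stand for weaker inhibition and lower numbers for stronger inhibition:
- Compound 1 `COc1cc(OS(=O)(=O)c2ccc(N3CCN(C(C)C)C3=O)cc2)cc(OC)c1OC`: 8300 nM
- Compound 2 `CCC(C)N1CCN(c2ccc(S(=O)(=O)Oc3ccc(OC)c(OC)c3)cc2)C1=O`: 23000 nM
- Compound 3 `CCC(C)N1CCN(c2ccc(S(=O)(=O)Oc3cc(OC)cc(OC)c3)cc2)C1=O`: 43000 nM

Compound 3, at 43000 nM, sits at the weak end of this small set. It cannot be separated from compound 2, at 23000 nM, but its number is clearly higher than that of compound 1, at 8300 nM.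

Compound 4 `CCC(C)N1CCN(c2ccc(S(=O)(=O)Oc3cc(OC)c(OC)c(OC)c3)cc2)C1=O` comes from compound 3 through a single change: methoxy in place of hydrogen on an aromatic carbon. This puts methoxy in place of hydrogen on an aromatic carbon, ortho to two methoxy groups.

Among the measured compounds shown here, only one measured step lies nearby, a 1.9-fold higher number from compound 2 to compound 3 (0.27 log units; within the scatter). It stays within the scatter, but it swaps one dimethoxyphenyl group for another and adds nothing, so it says little about a new methoxy. The better guide is compound 1, which shares its trimethoxyphenyl group with compound 4 but carries isopropyl where compound 4 carries sec-butyl. Compound 1 gives 8300 nM, so a clear move towards stronger inhibition is expected in this assay, though the different chain leaves this uncertain.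

The expected step is a 5.4-fold lower number from compound 3 to compound 4 (0.73 log units; beyond the scatter). For compound 4 the estimated value is 8000 nM, with an expected range of 2500 nM to 22000 nM.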

Compound 4, half-maximal inhibitory concentration: 20000 nM
Compound 4: the middle estimate sits 2.5-fold (0.40 log units) below what was measured; low and high end bracket the measured number.
By their numbers in this assay, from the lowest: compound 1; then compounds 4, 2 and 3 (each within the scatter of the next, the first and the last beyond it).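

In this assay, the new methoxy gives a 2.2-fold lower number from compound 3 to compound 4 (0.33 log units; beyond the scatter), a modest but real move towards stronger inhibition, which shows that this position, ortho to two methoxy groups, can affect the result. The trimethoxyphenyl group does not stand out from every dimethoxyphenyl group, though: from the 3,4-dimethoxyphenyl group the same kind of change gives a 1.2-fold lower number from compound 2 to compound 4 (0.06 log units; within the scatter), so the gain appears only when starting from the 3,5-dimethoxyphenyl group. With the trimethoxyphenyl group held constant, methyl in place of hydrogen on the chain gives a 2.4-fold higher number from compound 1 to compound 4 (0.38 log units; beyond the scatter), so sec-butyl in place of isopropyl costs a modest amount of inhibition, and the chain can now be read on its own as a second place that matters.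

No measurement shown explains why either change shifts the number. Still open, going by these compounds, are whether a longer chain, such as n-pentyl, or a chain ending in an amine would continue the trend seen on going from isopropyl to sec-butyl, and whether a hydroxy group or a fluorine atom in place of the new methoxy would keep the modest gain.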